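From carboxymethyl to 2-hydroxypropyl on a sulfonamide nitrogen

A few compounds are considered here, and "the series" means these few. Any claim that something is new, unique, unknown or untested is made for them only; others in the source may bear on it.

In an ADME assay on the whole organism (plasma, strain Sprague-Dawley) for pharmacokinetics, with Rattus norvegicus as the target, at a dose of 5 mg/kg by the oral route (a higher number here means more compound in the circulation at the dose given, a lower number less compound in the circulation), compound 2 `CS(=O)(=O)N(CC(=O)O)c1c(Cl)c(Cl)cc2[nH]c(=O)c(=O)[nH]c12` gives 393 ng.h/mL as the higher of two numbers, and compound 1 `CS(=O)(=O)N(CCCO)c1c(Cl)c(Cl)cc2[nH]c(=O)c(=O)[nH]c12` gives 136 ng.h/mL as the lower. Compound 3 `CC(O)CN(c1c(Cl)c(Cl)cc2[nH]c(=O)c(=O)[nH]c12)S(C)(=O)=O` differs from compound 2 by 1-hydroxyethyl in place of carboxy on a saturated chain carbon bound to a sulfonamide nitrogen with 1-hydroxyethyl in place of carboxy on a saturated chain carbon bound to a sulfonamide nitrogen. Among the measured compounds shown here, only one measured step bears on this change, the modest 2.9-fold higher number from compound 1 to compound 2 (0.46 log units; beyond the scatter) which put carboxy in place of 2-hydroxyethyl at that place. A step of similar size in the opposite direction is therefore expected, estimated as a 2.6-fold lower number from compound 2 to compound 3 (0.42 log units; beyond the scatter) for this change. In this assay compound 3 is expected at 150 ng.h/mL within the range 50 ng.h/mL to 450 ng.h/mL as an estimate.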

Compound 3, area under the concentration-time curve in the Rattus norvegicus assay: 680 ng.h/mL
Compound 3: middle estimate off by 4.5-fold (0.66 log units), on the low side; the measured number lies above the stated range.
By their numbers in the Rattus norvegicus assay, from the lowest: compound 1; then compounds 2 and 3 (each within the scatter of the next).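

In the Rattus norvegicus assay compound 2 gives 393 ng.h/mL and compound 3 gives 680 ng.h/mL, and the step of a 1.7-fold higher number from compound 2 to compound 3 (0.24 log units; within the scatter) stays within the scatter, so on this saturated chain carbon bound to a sulfonamide nitrogen, 1-hydroxyethyl reads level with carboxy. With the Rattus norvegicus assay again, the step of a 5.0-fold higher number from compound 1 to compound 3 (0.70 log units; beyond the scatter) shows what the earlier pair could not: 1-hydroxyethyl and 2-hydroxyethyl are not equivalent at this place. In a physicochemical assay for solubility (on this read-out lower numbers stand for lower solubility and higher numbers for higher solubility), compound 2 gives 76 ug/mL and compound 3 gives 76 ug/mL, and the same change gives no change at the digits printed from compound 2 to compound 3 (within the scatter), so that read-out stays level too. Going by these compounds, whether an amine or a longer chain would hold up at this place remains open. Nothing available gives a reason for these steps.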